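Removing a Ring Bromine from a Triazole-Bearing Polycyclic Scaffold

A few compounds are considered here, and "the series" means these few. Any claim that something is new, unique, unknown or untested is made for them only; others in the source may bear on it.

compound 1 `Cc1ccc(S(=O)(=O)Oc2ccc3c(c2C)[C@H](Cn2cc(-c4ccccc4)nn2)[C@@]24CC(=O)[C@@](C)(CC[C@@H]32)C4)cc1` — > 20000 nM
compound 2 `Cc1ccc(S(=O)(=O)Oc2ccc3c(c2C)[C@H](Cn2cc(-c4ccc(Br)cc4)nn2)[C@@]24CC(=O)[C@@](C)(CC[C@@H]32)C4)cc1` — > 20000 nM
compound 3 `C=C1C[C@]23C[C@@]1(O)CC[C@H]2c1cc(Br)c(O)c(C)c1[C@@H]3Cn1cc(-c2ccc(Cl)cc2)nn1` — 5590 nM

Of the compounds shown here, three have been tested in a functional assay on HL-60 cells (Homo sapiens) for cytotoxicity, read by MTT assay, with a stated time of 4 days; on this read-out higher numbers stand for weaker inhibition and lower numbers for stronger inhibition. For compound 1 the result of > 20000 nM is a limit of the assay and not a number. For compound 2 the result of > 20000 nM is likewise a limit. Among the compounds with values here, compound 3 is the only one to give a number, 5590 nM. Compound 1 differs from compound 2 by hydrogen in place of bromo on an aromatic carbon; the step that the two limits leave unreadable from compound 2 to compound 1 has no readable size because both values sit at the limit of > 20000 nM in this assay, at which 2 of the 3 values shown sit. The cores of compound 2 and compound 3 differ, and that difference is not broken down here.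

Compound 4 `C=C1C[C@]23C[C@@]1(O)CC[C@H]2c1ccc(O)c(C)c1[C@@H]3Cn1cc(-c2ccc(Cl)cc2)nn1` has not yet been measured. It differs from compound 3 by hydrogen in place of bromo on an aromatic carbon. Within the data shown here, this is the same kind of change as the one from compound 2 to compound 1, but the surroundings differ: in compound 3 the carbon is part of a fused or bridged system of four rings, ortho to a hydroxy group, meta to a fused ring, meta to a methyl group and para to a fused ring, whereas in compound 2 it is para to a large group. Since the earlier step is unreadable, the expectation rests only on the value of compound 3, 5590 nM, and on the small size of what is removed. Compound 4 is expected to give about 8000 nM, within 2500 nM to 25000 nM. The expected step is a 1.4-fold higher number from compound 3 to compound 4 (0.16 log units; within the scatter).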

Compound 4, half-maximal inhibitory concentration: > 20000 nM
Compound 4: no number, only a limit; the forecaster's own chance of this, stated with the estimate: 30%; middle value at least 2.5-fold (0.39 log units) away from the limit.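

In this assay, hydrogen in place of bromo on the aromatic carbon ortho to a hydroxy group gives an at least 3.5-fold higher number from compound 3 to compound 4 (0.55 log units; beyond the scatter), so on this core the loss of the single bromine atom is a change that can be seen. Going by these compounds, how large the step really is stays open because compound 4 gives a limit of the assay and not a number, which fixes only a smallest size for the step: the limit of > 20000 nM in this assay, at which 3 of the 4 values shown sit. The same exchange on the other core, where the carbon is para to a large group, cannot be read, since compound 2 and compound 1 both sit at that limit, so the series shows neither that the change carries over from one core to the other nor that it fails to.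

The compounds shown leave open whether the bromo group is the only substituent at this aromatic carbon that goes with a measurable number in this assay, or whether an amine, a methoxy group or a nitrile there would do the same. Also open, on these data alone, is how a carboxylic acid or a longer alkyl chain in place of the hydroxy group on that ring would read, with the bromo group kept.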